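Pyrazolyl for Pyrimidinyl: Expected Clearance of Compound 3

The compounds below may be only part of what the source reports. "The series", "measured", "known", "first", "only" and "open" are said of these compounds alone.

Compound 2 `Cc1cc(-c2ncccn2)cc(C(=O)NNS(=O)(=O)c2ccccc2)c1F` and compound 1 `O=C(NNS(=O)(=O)c1ccccc1F)c1cc(F)cc(-c2ccccn2)c1` were assessed in an ADME assay on microsomes from liver (Homo sapiens) for metabolic stability, read by HPLC, using NADPH, with a stated time of 60 min, tested at 1 uM, in the presence of a further agent that is not named here; on this read-out higher numbers stand for fast clearance and lower numbers for slow clearance. Compound 1 gives 31 uL/min, and compound 2 gives 11 uL/min, the lower of the two numbers, with its gap to compound 1 beyond the usual scatter. Compound 3 `Cc1cc(-n2cccn2)cc(C(=O)NNS(=O)(=O)c2ccccc2)c1F` differs from compound 2 in one place: 1H-pyrazol-1-yl in place of pyrimidin-2-yl on an aromatic carbon. Within the data shown here, no measured pair shows this change, so the step is expected to be modest, probably within the scatter, leaning slightly toward a higher number, which is what a 1.4-fold higher number from compound 2 to compound 3 (0.13 log units; within the scatter) expresses. On that basis compound 3 is estimated at 15 uL/min, within a range from 7 uL/min to 35 uL/min.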

Compound 3, intrinsic clearance in a liver preparation (reported as CLH), per the amount of preparation that the assay uses: 23 uL/min
The estimate for compound 3 lay 1.5-fold (0.19 log units) below the measured number; measured number inside the range.
By their numbers in this assay, from the lowest: compound 2; then compounds 3 and 1 (each within the scatter of the next).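

At this position, on an aromatic carbon para to the fluoro group, 1H-pyrazol-1-yl in place of pyrimidin-2-yl gives a 2.1-fold higher number from compound 2 to compound 3 (0.32 log units; beyond the scatter) in this assay, so this single change moves clearance beyond the scatter. The two groups have the same counts of hetero atoms, hydrogen-bond donors and hydrogen-bond acceptors, so those counts alone do not fix the number. Nothing measured here accounts for the step. Open, as far as these compounds go, is how an amine or a carboxylic acid on this carbon would read, and whether the same change would give a similar step on the core of compound 1.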